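The source may report more compounds than this note shows. Statements on the series, on what has been measured and on what is new or still open speak of the compounds shown alone.

For the measured compounds named here, in a functional assay on MCF7 cells (Homo sapiens) for inhibition, read by sulforhodamine B assay (a higher number here means a weaker inhibitor, a lower number a stronger inhibitor), compound 2 (`O=C1C=C(Nc2ccccc2F)C(=O)c2c1nc1n2[C@H]2OC[C@@H](O)[C@H]2OC1`) gives 3640 nM, the only actual number so far. Compound 1 (`O=C1C(Nc2ccccc2)=CC(=O)c2c1nc1n2[C@H]2OC[C@@H](O)[C@H]2OC1`) reads > 4000 nM, which is a limit. Compound 3 (`O=C1C(N2CCCCC2)=CC(=O)c2c1nc1n2[C@H]2OC[C@@H](O)[C@H]2OC1`) reads > 8000 nM, also a limit. Compound 4 (`O=C1C=C(Nc2ccc(C(F)(F)F)cc2)C(=O)c2c1nc1n2[C@H]2OC[C@@H](O)[C@H]2OC1`) differs from compound 2 in the group on the amine nitrogen: 4-(trifluoromethyl)phenyl in place of 2-fluorophenyl on an amine nitrogen. Going by the values given here, the one measured step, a step that the two limits leave unreadable from compound 1 to compound 3, has no readable size and concerns a different change, so it gives no measure to carry over. Compound 2 at 3640 nM is therefore the sole anchor, and no step beyond the scatter is expected in this assay. The expected step is a 1.0-fold lower number from compound 2 to compound 4 (0.02 log units; within the scatter). Compound 4 is estimated at 3500 nM, with an expected range of 1300 nM to 9000 nM.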

Compound 4, half-maximal inhibitory concentration: > 4000 nM
Compound 4: only a limit was reported (the forecaster's own chance of this, stated with the estimate: 35%); middle value at least 1.1-fold (0.05 log units) from the limit.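

In this assay, 4-(trifluoromethyl)phenyl in place of 2-fluorophenyl on the amine nitrogen gives an at least 1.0-fold higher number from compound 2 to compound 4 (0.04 log units; that floor lies within the scatter), so this exchange of aryl groups at this position offers no sign of a lower number, and only a floor for the step is known. The reading of compound 4 is a limit, and compound 1 carries the same limit: the limit of > 4000 nM in this assay, at which 2 of the 4 values shown sit.

On these data alone, the true value of compound 4 remains open. Also open, as far as these compounds go, is whether a benzyl group or a longer alkyl chain on this amine nitrogen would give a measurable number.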